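A few compounds are considered here, and "the series" means these few. Any claim that something is new, unique, unknown or untested is made for them only; others in the source may bear on it.

Measured so far in a functional assay, tested at 10 uM; on this read-out higher numbers stand for a stronger effect at the one concentration tested and lower numbers for a weaker effect:

compound 1 `COP(=O)(OC)[Se]c1ccccc1`: 5.02%
compound 2 `CCCCOP(=O)(OCCCC)[Se]c1ccccc1`: 1.92%
compound 3 `O=P(OCc1ccccc1)(OCc1ccccc1)[Se]c1ccccc1`: 3.85%

All three measured compounds share the same core and differ only in the two ester groups on phosphorus. In this assay compound 1 gives 5.02%, the highest of the three numbers. Compound 3 gives 3.85% and compound 2 gives 1.92%; both lie within the scatter of the number for compound 1, so the three numbers cannot be told apart and none of the three compounds can be called more or less active than the others.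

Compound 4 `COP(=O)(OC)[Se]c1ccc(C)cc1` has not yet been measured. It differs from compound 1 in one place: methyl in place of hydrogen on an aromatic carbon. Among the compounds with values here, no pair of measured compounds that differ in a single place exists here, so there is no measured step to set this change against. With compound 1 at 5.02%, compound 3 at 3.85% and compound 2 at 1.92% sitting close together, the step expected for compound 4 is small, a number 0 percentage points lower from compound 1 to compound 4 (within the scatter), in no particular direction and not beyond the scatter. Compound 4 is therefore estimated at 5%, with a range from 0% to 12%.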

Compound 4, a percentage reported as activity, at one concentration (the size of the read-out at that concentration, not a potency): 11.5%
For compound 4 the middle estimate is 6.5 percentage points below the measured one; measured number inside the range.
By their numbers in this assay, from the lowest: compounds 2, 3, 1 and 4 (each within the scatter of the next).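

In this assay the shared core now has its first measured step on the aromatic ring, rather than in the ester groups on phosphorus: a number 6.5 percentage points higher from compound 1 to compound 4 (within the scatter) for methyl in place of hydrogen on an aromatic carbon, para to a group of 7 heavy atoms. Since this step is printed as within the scatter, methyl at this position cannot be told apart from hydrogen, and no direction can be claimed for the change. Nothing measured here bears on the reason for this step.

Going by these compounds, it remains open whether another group at this position, such as a methoxy group, a chlorine atom, an amine or a carboxylic acid, would move the number beyond the scatter. On these data alone, it is also open whether methyl would give a similar step on the compounds carrying butyl or benzyl esters on phosphorus.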